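Working notes: methoxy in place of methyl

The source may report more compounds than this note shows. Statements on the series, on what has been measured and on what is new or still open speak of the compounds shown alone.

Measured in a functional assay on A-431 cells (Homo sapiens) for antiproliferative activity, read by sulforhodamine B assay, with a stated time of 72 h; a higher number here means a weaker inhibitor, a lower number a stronger inhibitor:
- compound 1 `C=C1CC(CBr)(c2ccccc2)OC1=O`: 1480 nM
- compound 2 `C=C1CC(CBr)(c2ccc(C)cc2)OC1=O`: 2200 nM

The two measured compounds cannot be told apart in this assay: compound 2 at 2200 nM lies within the scatter of compound 1 at 1480 nM. The next compound to be measured is compound 3 `C=C1CC(CBr)(c2ccc(OC)cc2)OC1=O`, which carries methoxy in place of methyl on an aromatic carbon.

Among the measured compounds shown here, only one measured step bears on this change, namely a 1.5-fold higher number from compound 1 to compound 2 (0.17 log units; within the scatter), which is methyl in place of hydrogen on an aromatic carbon. It involves the same place on the ring but not the methoxy group, so the evidence is thin. No data yet show how methoxy behaves in this series. On that single step, no change beyond the scatter is expected in this assay, and no direction can be assigned with confidence. The expected step is a 1.1-fold lower number from compound 2 to compound 3 (0.04 log units; within the scatter). For compound 3 the estimate is 2000 nM, with an expected range of 900 nM to 4500 nM.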

Compound 3, half-maximal inhibitory concentration: 4200 nM
Estimate against measurement, compound 3: 2.1-fold (0.32 log units) below; the measured number falls inside the stated range.
By their numbers in this assay, from the lowest: compounds 1, 2 and 3 (each within the scatter of the next, the first and the last beyond it).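

In this assay, methoxy in place of methyl on this aromatic carbon gives a 1.9-fold higher number from compound 2 to compound 3 (0.28 log units; within the scatter), so this change alone cannot be separated from the scatter. Methoxy in place of hydrogen at the same place gives a 2.8-fold higher number from compound 1 to compound 3 (0.45 log units; beyond the scatter), a modest step and the first in the series to pass the scatter, which shows that a group on this aromatic carbon can give a weaker inhibitor than hydrogen, although methyl has not shown this. No measurement is available that bears on the reason for this difference.

The compounds shown carry only hydrogen, methyl and methoxy at this place, so it remains open whether the step from hydrogen is particular to methoxy or would also appear with other groups. An amine, a carboxylic acid or a longer chain such as ethoxy on the same aromatic carbon would test this, and would also show whether any group here can give a lower number than compound 1 at 1480 nM.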